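Vero cytotoxicity notes: shortening the diethylamino chain

The compounds below may be only part of what the source reports. "The series", "measured", "known", "first", "only" and "open" are said of these compounds alone.

compound 1 `CCOC(=O)Nc1cc(NC(C)CCCN(CC)CC)c2nc(-c3cccs3)c(-c3cccs3)nc2n1`: > 40000 nM
compound 2 `CCOC(=O)Nc1cc(NC(C)CCCN(CC)CC)c2nc(CC)c(CC)nc2n1`: > 40000 nM
compound 3 `CCOC(=O)Nc1cc(NCCCCN(CC)CC)c2nc(-c3ccccc3)c(-c3ccccc3)nc2n1`: 1800 nM

In an ADME assay on Vero cells (Chlorocebus sabaeus) for cytotoxicity, read by CellTiter-Glo, with a stated time of 72 h (on this read-out lower numbers stand for higher toxicity in this test and higher numbers for lower toxicity in this test), compound 1 returns only a limit, > 40000 nM. Compound 2 likewise returns only a limit, > 40000 nM. Compound 3 gives a number, 1800 nM. Compound 1 thus stands at the limit of > 40000 nM in this assay, at which 2 of the 3 values shown sit. Compound 3 alone lies inside the measured range. For the measured compounds named here, no pair of measured compounds differs in a single place, so no measured step is available.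

Compound 4 `CCOC(=O)Nc1cc(NCCN(CC)CC)c2nc(-c3cccs3)c(-c3cccs3)nc2n1`, not yet measured, differs from compound 1 by 2-(diethylamino)ethyl in place of 4-(diethylamino)-1-methylbutyl on a nitrogen on an aromatic ring. With nothing measured to lean on, no movement in this assay beyond the usual scatter is expected, and compound 4 is expected to stay at the limit. The expected step is a number no higher from compound 1 to compound 4 (the limit leaves the size open). Compound 4 is estimated at 40000 nM, between 15000 nM and 90000 nM.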

Compound 4, half-maximal cytotoxic concentration: 6300 nM
Beside the measured number, compound 4's estimate is 6.3-fold (0.80 log units) above it; measured number outside the range, below it.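

In this assay the change to 2-(diethylamino)ethyl on a nitrogen on an aromatic ring gives an at least 6.3-fold lower number from compound 1 to compound 4 (0.80 log units; beyond the scatter) and shows that this side chain alone moves the read-out off the limit, with the core of compound 1 held fixed. As far as these compounds go, compound 1 is held at a limit, so the full size of the step stays open: the limit of > 40000 nM in this assay, at which 2 of the 4 values shown sit.

The compounds shown leave open how a morpholine or pyrrolidine in place of the diethylamino group would read on this core. They also leave open whether an unbranched butyl linker on this core would read nearer compound 1 or compound 4.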